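Changing the Aryl Group on the Ring Nitrogen

A few compounds are considered here, and "the series" means these few. Any claim that something is new, unique, unknown or untested is made for them only; others in the source may bear on it.

Of the compounds shown here, three sharing one core have been tested in a functional assay on LoVo cells (Homo sapiens) for inhibition, read by MTT assay, with a stated time of 24 h; on this read-out higher numbers stand for weaker inhibition and lower numbers for stronger inhibition. Compound 1 `CC1(C)[C@H]2CC[C@]1(C)N(Cc1cn(-c3ccccc3Cl)nn1)C(=O)C2` gives 190 nM, the second highest of the three numbers. Compound 2 `Cc1ccc(-n2cc(CN3C(=O)C[C@@H]4CC[C@@]3(C)C4(C)C)nn2)cc1` gives 50 nM, and compound 3 `CC1(C)[C@H]2CC[C@]1(C)N(Cc1cn(-c3ccccc3O)nn1)C(=O)C2` gives 540 nM. Going from compound 1 to compound 2 brings a 3.8-fold lower number from compound 1 to compound 2 (0.58 log units; beyond the scatter), while going from compound 1 to compound 3 brings a 2.8-fold higher number from compound 1 to compound 3 (0.45 log units; beyond the scatter); between compound 2 and compound 3 the gap is an 11-fold higher number from compound 2 to compound 3 (1.03 log units; beyond the scatter).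

Compound 4 `COc1cccc(-n2cc(CN3C(=O)C[C@@H]4CC[C@@]3(C)C4(C)C)nn2)c1` differs from compound 1 in a single place: 3-methoxyphenyl in place of 2-chlorophenyl on an aromatic nitrogen. The two measured steps that start from compound 1 point in opposite directions, a 4-methylphenyl giving a lower number and a 2-hydroxyphenyl a higher one. Within the data shown here, no measured compound carries a methoxy group, so the expectation can only be rough. Compound 4 is expected to give about 120 nM, within a range from 40 nM to 400 nM. The expected step is a 1.6-fold lower number from compound 1 to compound 4 (0.20 log units; within the scatter).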

Compound 4, half-maximal inhibitory concentration: 80 nM
Estimate against measurement, compound 4: 1.5-fold (0.18 log units) above; measured number inside the range.
By their numbers in this assay, from the lowest: compounds 2 and 4 (each within the scatter of the next); then compound 1; then compound 3.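

Putting 3-methoxyphenyl in place of 2-chlorophenyl gives a 2.4-fold lower number from compound 1 to compound 4 (0.38 log units; beyond the scatter), and putting it in place of 2-hydroxyphenyl gives a 6.8-fold lower number from compound 3 to compound 4 (0.83 log units; beyond the scatter), so the low numbers are not confined to the 4-methylphenyl of compound 2. The remaining step, a 1.6-fold higher number from compound 2 to compound 4 (0.20 log units; within the scatter), does not separate 3-methoxyphenyl from 4-methylphenyl, and both of these give lower numbers than 2-chlorophenyl and 2-hydroxyphenyl, with none of the four compounds going against that split. No measurement at hand explains this split.

From the compounds shown here alone, what a 2-methoxyphenyl or a 4-methoxyphenyl would give stays open, so the kind of group and its place on the aryl ring cannot yet be told apart. Going by these compounds, how an unsubstituted phenyl, or a phenyl carrying an amine or a carboxylic acid, would compare also remains unknown.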